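This account rests on a few compounds, and the source may have more. Where it says the series, first, only, none or still open, it means among the compounds named here.

Of the compounds shown here, three sharing one core have been measured in a functional assay on A549 cells (Homo sapiens) for inhibition, read by CCK-8 assay, with a stated time of 72 h, tested at 8 uM; on this read-out lower numbers stand for less inhibition of growth and higher numbers for more inhibition of growth at the one concentration tested. Compound 1 (`Nc1ccccc1NC(=O)/C=C/c1ccc(CSc2ccc(C(F)(F)F)cn2)cc1`) gives 56.5%, compound 2 (`Nc1ccccc1NC(=O)/C=C/c1ccc(CSc2ccc(F)cc2)cc1`) gives 59.1%, and compound 3 (`Nc1ccccc1NC(=O)/C=C/c1ccc(CSc2cccc3ccccc23)cc1`) gives 71.2%, the highest of the three. Compound 4 (`CC(C)(C)c1ccc(SCc2ccc(/C=C/C(=O)Nc3ccccc3N)cc2)cc1`) differs from compound 3 in one place: 4-(tert-butyl)phenyl in place of naphthalen-1-yl on a sulfur. Among the compounds with values here, two measured steps bear on this change, a number 12.1 percentage points higher from compound 2 to compound 3 (beyond the scatter) and a number 14.7 percentage points higher from compound 1 to compound 3 (beyond the scatter), both with naphthalen-1-yl entering. The remaining step, a number 2.6 percentage points higher from compound 1 to compound 2 (within the scatter), does not separate the other two groups. Within the data shown here, no measured compound carries 4-(tert-butyl)phenyl, so a downward step no larger than those two is expected in this assay. The expected change is a number 9.2 percentage points lower from compound 3 to compound 4 (within the scatter). Compound 4 is estimated at 62%, with an expected range of 49% to 74%.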

Compound 4, percent growth inhibition at one concentration: 79.8%
Beside the measured number, compound 4's estimate is 17.8 percentage points below it, and the stated range ends below it.
By their numbers in this assay, from the lowest: compounds 1 and 2 (each within the scatter of the next); then compounds 3 and 4 (each within the scatter of the next).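

In this assay, a single ring of carbon carrying tert-butyl on a sulfur gives a number within the scatter of naphthalen-1-yl, with a number 8.6 percentage points higher from compound 3 to compound 4 (within the scatter), so the second aromatic ring of naphthalen-1-yl is not required at this position. Both a number 20.7 percentage points higher from compound 2 to compound 4 (beyond the scatter) and a number 23.3 percentage points higher from compound 1 to compound 4 (beyond the scatter) show that the choice of group on the single ring matters here. Nothing shown gives a cause for these steps. As far as these compounds go, whether an amine or a carboxylic acid in place of tert-butyl on an aromatic carbon would give a number of this size stays open. So does the outcome with a cyclohexyl group on the sulfur.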